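The source may hold more compounds than are shown below. What is called first, only, known or untested is meant among the compounds shown, and "the series" means these compounds.

In an ADME assay on HEL cells (Homo sapiens) for cytotoxicity, with a stated time of 3 days (a lower number here means that less compound is tolerated, a higher number that more compound is tolerated), compound 3 `Cc1cc(N2CCCC2=O)cn2c(CSCCc3ccccc3)cnc12` gives 89 ug/mL, the highest of the three numbers recorded. Compound 2 `Cc1cc(-c2ccoc2)cn2c(CSCCc3ccccc3)cnc12` gives 12 ug/mL, and compound 1 `Cc1cc(-c2ccsc2)cn2c(CSCc3ccccc3)cnc12` gives 9.4 ug/mL; these two values lie close to each other. Within the data shown here, the only single-point change among the measured compounds is a 7.4-fold higher number from compound 2 to compound 3 (0.87 log units; beyond the scatter), where 2-oxopyrrolidin-1-yl took the place of furan-3-yl. Compound 4 `Cc1cc(Sc2ccc(O)cc2)cn2c(CSCCc3ccccc3)cnc12` differs from compound 3 at that same position: (4-hydroxyphenyl)sulfanyl in place of 2-oxopyrrolidin-1-yl on an aromatic carbon. Among the measured compounds shown here, no measured pair covers this exact exchange, so the expectation rests on the one known step. That step raised the number when furan-3-yl left and 2-oxopyrrolidin-1-yl entered; here 2-oxopyrrolidin-1-yl leaves again and a group built on one six-membered aromatic ring of carbon only enters, so a step back down of roughly comparable size is expected, a 5.9-fold lower number from compound 3 to compound 4 (0.77 log units; beyond the scatter). Compound 4 is therefore estimated to give 15 ug/mL in this assay, with a likely range from 5 ug/mL to 50 ug/mL.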

Compound 4, half-maximal cytotoxic concentration: 100 ug/mL
Compound 4: the middle estimate sits 6.7-fold (0.82 log units) below what was measured, outside the stated range (above it).
By their numbers in this assay, from the lowest: compounds 1 and 2 (each within the scatter of the next); then compounds 3 and 4 (each within the scatter of the next).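

In this assay, a 1.1-fold higher number from compound 3 to compound 4 (0.05 log units; within the scatter) shows that (4-hydroxyphenyl)sulfanyl and 2-oxopyrrolidin-1-yl cannot be told apart at this position, although one carries a six-membered aromatic ring of carbon only and the other a five-membered non-aromatic ring. Until now, only 2-oxopyrrolidin-1-yl had been seen to raise the number when it replaced furan-3-yl; an 8.3-fold higher number from compound 2 to compound 4 (0.92 log units; beyond the scatter) shows a second replacement doing so. An aromatic ring in the group on this aromatic carbon therefore does not by itself go with the lower number of compound 2.

No measurement is available that could explain these numbers. From the compounds shown here alone, whether an amine or a carboxylic acid here would sit with compound 2 or with compound 3 and compound 4 stays open, as does the part played by the sulfur atom and the hydroxyl group of compound 4.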